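The compounds below may be only part of what the source reports. "The series", "measured", "known", "first", "only" and "open" are said of these compounds alone.

Measured in a functional assay on the whole organism for inhibition, with Mus musculus as the target; a higher number here means that more compound is needed for the effect, a lower number that less compound is needed:
Compound 1 `CCN1CCCC1CNC(=O)c1cc(N(C)S(C)(=O)=O)c(C)cc1OC` gives 26.1 mg/kg.
Compound 2 `CCN1CCCC1CNC(=O)c1cc(N(C)S(C)(=O)=O)c(Cl)cc1OC` gives 7.7 mg/kg.
Compound 3 `CCN1CCCC1CNC(=O)c1cc(NS(=O)(=O)NC)c(C)cc1OC` gives > 50 mg/kg.

For compound 3 that value is only a limit of the assay, not a number. Compound 2 differs from compound 1 by chloro in place of methyl on an aromatic carbon, and that change made a 3.4-fold lower number from compound 1 to compound 2 (0.53 log units; beyond the scatter). As far as these compounds go, compound 3 differs from compound 1 in the core, by (methylsulfamoyl)amino in place of methyl(methylsulfonyl)amino on an aromatic carbon, with an at least 1.9-fold higher number from compound 1 to compound 3 (0.28 log units; that floor lies within the scatter); the result for compound 3 sits at the limit of > 50 mg/kg in this assay, at which 1 of the 3 values shown sits, so the true size of that step stays open. The unmeasured compound 4 `CCN1CCCC1CNC(=O)c1cc(NS(=O)(=O)NC)c(Cl)cc1OC` carries the same kind of change relative to compound 3 as compound 2 carries relative to compound 1: chloro in place of methyl on an aromatic carbon. It is not the same change, since the surroundings differ: here the chloro is ortho to a (methylsulfamoyl)amino group, whereas in compound 2 it is ortho to a methyl(methylsulfonyl)amino group. The expected step, resting on a 3.4-fold lower number from compound 1 to compound 2 (0.53 log units; beyond the scatter), is an at least 1.6-fold lower number from compound 3 to compound 4 (0.22 log units; that floor lies within the scatter). The estimate for compound 4 is 30 mg/kg, with a range from 10 mg/kg to 100 mg/kg, and a fair chance that this assay again reports only a limit.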

Compound 4, dose for half-maximal effect: > 50 mg/kg
Compound 4: a limit, no number; the forecaster's own chance of this, stated with the estimate: 40%; middle value at least 1.6-fold (0.22 log units) away from the limit.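

In this assay compound 4 gives > 50 mg/kg, which is a limit of the assay and not a number. On the chloro-bearing core, the (methylsulfamoyl)amino group in place of the methyl(methylsulfonyl)amino group gives an at least 6.4-fold higher number from compound 2 to compound 4 (0.81 log units; beyond the scatter), while the step between compound 3 and compound 4 cannot be read, since both results are limits. This shows a higher number beyond the scatter on the core of compound 2, but it does not show whether the change has the same size on both cores: the same change on two cores in this assay, an at least 1.9-fold higher number (0.28 log units; that floor lies within the scatter) from compound 1 to compound 3 and an at least 6.4-fold higher number (0.81 log units; beyond the scatter) from compound 2 to compound 4; the limit leaves it open whether they differ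

Still open, as far as these compounds go, is how far the true values of compound 3 and compound 4 lie past the limit, and so whether chloro in place of methyl lowers the number alongside the (methylsulfamoyl)amino group as it does from compound 1 to compound 2. Also open, from the compounds shown here alone, is how a bromo group in place of the chloro, or an acetylamino group in place of the (methylsulfamoyl)amino group, would read in this assay.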